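Swapping Isopropoxy for Methylcarbamoyl on the Shared Core

The source may report more compounds than this note shows. Statements on the series, on what has been measured and on what is new or still open speak of the compounds shown alone.

Measured in a functional assay on HeLa cells (Homo sapiens) for antiproliferative activity, read by CCK-8 assay, with a stated time of 72 h; a lower number here means a stronger inhibitor, a higher number a weaker inhibitor:
- compound 1 `COc1cc(-c2ncncc2-c2ccc(SC)cc2)cc(OC)c1OC`: 220 nM
- compound 2 `CCSc1ccc(-c2cncnc2-c2cc(OC)c(OC)c(OC)c2)cc1`: 370 nM
- compound 3 `COc1cc(-c2ncncc2-c2ccc(OC(C)C)cc2)cc(OC)c1OC`: 8360 nM

Of these three, compound 3 is the weakest inhibitor in this assay, at 8360 nM. The next structure is compound 4 `CNC(=O)c1ccc(-c2cncnc2-c2cc(OC)c(OC)c(OC)c2)cc1`, and it differs from compound 3 in one place: methylcarbamoyl in place of isopropoxy on an aromatic carbon. In short, methylcarbamoyl sits in place of isopropoxy on an aromatic carbon, para to a large group.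

Within the data shown here, two measured steps concern this same place. Both are large: a 38-fold higher number from compound 1 to compound 3 (1.58 log units; beyond the scatter), and a 23-fold higher number from compound 2 to compound 3 (1.35 log units; beyond the scatter). A smaller change on the sulfur chain gave a 1.7-fold higher number from compound 1 to compound 2 (0.23 log units; within the scatter). So the group at this place can matter a great deal, but no measured compound carries methylcarbamoyl, and the data cannot show directly what it will do.

Isopropoxy appears only in compound 3, at 8360 nM, so removing it may recover some activity. A full return to the level of the sulfur compounds is not assumed. The expected change is moderate and towards a lower number: a 2.8-fold lower number from compound 3 to compound 4 (0.45 log units; beyond the scatter). The estimated value for compound 4 is 3000 nM, with an expected range of 500 nM to 15000 nM.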

Compound 4, half-maximal inhibitory concentration: 1470 nM
Beside the measured number, compound 4's estimate is 2.0-fold (0.31 log units) above it; the measured number falls inside the stated range.
By their numbers in this assay, from the lowest: compounds 1 and 2 (each within the scatter of the next); then compound 4; then compound 3.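

In this assay, this position responds to more than the count of heavy atoms: the change to methylcarbamoyl gives a 5.7-fold lower number from compound 3 to compound 4 (0.75 log units; beyond the scatter) even though methylcarbamoyl and isopropoxy each hold 4 heavy atoms. The two groups differ in makeup, since methylcarbamoyl brings a nitrogen, a carbonyl and 1 hydrogen-bond donor, but this single step cannot show which of these features matters. The recovery is only partial. Measured against the sulfur compounds, methylcarbamoyl gives a 4.0-fold higher number from compound 2 to compound 4 (0.60 log units; beyond the scatter) and a 6.7-fold higher number from compound 1 to compound 4 (0.82 log units; beyond the scatter), which places compound 4 between the sulfur compounds and compound 3. No measurement here explains why these groups differ.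

The compounds shown do not separate the effect of the amide hydrogen from that of the carbonyl, a question that a dimethylcarbamoyl group, with no amide hydrogen, or an unsubstituted carbamoyl group at the same place could help to answer. They also leave open how a carboxylic acid, an amine or a methoxy group would behave there, and whether any oxygen-linked group can approach the sulfur compounds.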